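The source may report more compounds than this note shows. Statements on the series, on what has been measured and on what is new or still open speak of the compounds shown alone.

Working notes on the series. Compound 3 `Cc1cc(C)c(NC(=O)N(Cc2ccc(-c3ccnn3C)cc2)C2CCCCCC2)c(C)c1` gives 24 nM in an assay on microsomes from intestine for inhibition of acyl-CoA:cholesterol acyltransferase (Oryctolagus cuniculus) (a higher number here means a weaker inhibitor, a lower number a stronger inhibitor), and stands lowest of the three numbers measured. Compound 1 `Cc1cc(C)c(NC(=O)N(Cc2ccc(-n3cccn3)cc2)C2CCCCCC2)c(C)c1` gives 70 nM in this assay, and compound 2 `Cc1cc(C)c(NC(=O)N(Cc2ccc(-c3cn[nH]c3)cc2)C2CCCCCC2)c(C)c1` gives 270 nM. The steps to compound 3 both fall: a 2.9-fold lower number from compound 1 to compound 3 (0.46 log units; beyond the scatter) and an 11-fold lower number from compound 2 to compound 3 (1.05 log units; beyond the scatter), while a 3.9-fold higher number from compound 1 to compound 2 (0.59 log units; beyond the scatter) separates the two other rings.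

Compound 4 `Cc1cc(C)c(NC(=O)N(Cc2ccc(-n3cncn3)cc2)C2CCCCCC2)c(C)c1` differs from compound 3 in one place: 1H-1,2,4-triazol-1-yl in place of 1-methyl-1H-pyrazol-5-yl on an aromatic carbon. Within the data shown here, no measured step covers this exact change; the closest precedent is compound 1 with 1H-pyrazol-1-yl, and a 2.9-fold lower number from compound 1 to compound 3 (0.46 log units; beyond the scatter) is the step that bears on it. A modest rise toward the number of compound 1 is therefore expected, a 2.5-fold higher number from compound 3 to compound 4 (0.40 log units; beyond the scatter). Compound 4 is estimated at 60 nM, with a range from 25 nM to 150 nM.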

Compound 4, half-maximal inhibitory concentration: 26 nM
Beside the measured number, compound 4's estimate is 2.3-fold (0.36 log units) above it; measured number inside the range.
By their numbers in this assay, from the lowest: compounds 3 and 4 (each within the scatter of the next); then compound 1; then compound 2.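

At this position, para to a large group, the 1H-1,2,4-triazol-1-yl ring holds up against the 1-methyl-1H-pyrazol-5-yl ring, with a 1.1-fold higher number from compound 3 to compound 4 (0.03 log units; within the scatter). Among rings attached through nitrogen, 1H-1,2,4-triazol-1-yl also improves on 1H-pyrazol-1-yl, with a 2.7-fold lower number from compound 1 to compound 4 (0.43 log units; beyond the scatter), and the gap to the 1H-pyrazol-4-yl ring stays wide, with a 10-fold lower number from compound 2 to compound 4 (1.02 log units; beyond the scatter). No measurement available here accounts for these steps. Still open, as far as these compounds go, is how a methyl group or an amine on the 1H-1,2,4-triazol-1-yl ring would shift the number.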